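Swapping an Ethyl for 1-Methylethenyl on a Thiophene Amine

This account rests on a few compounds, and the source may have more. Where it says the series, first, only, none or still open, it means among the compounds named here.

Measured so far:
Compound 1, `CCc1csc(CN[C@@H]2C[C@H]3C[C@@H]([C@H]2C)C3(C)C)c1`, gives 25000 nM in an ADME assay on MDCK cells (Canis lupus familiaris) for cytotoxicity, read by microscopy, with a stated time of 48 h; a lower number here means that less compound is tolerated, a higher number that more compound is tolerated.
Compound 2, `CCOc1ccsc1CN[C@@H]1C[C@H]2C[C@@H]([C@H]1C)C2(C)C`, gives 50000 nM in this assay.

The two numbers from compound 1 and compound 2 lie within the usual scatter of each other, so compound 1 is not set apart from compound 2 in this assay. Compound 3, `C=C(C)c1csc(CN[C@@H]2C[C@H]3C[C@@H]([C@H]2C)C3(C)C)c1`, differs from compound 1 by 1-methylethenyl in place of ethyl on an aromatic carbon. No comparable change has been measured here, so no step beyond the scatter is expected in this assay. Compound 3 is therefore estimated at 25000 nM, between 12500 nM and 50000 nM, a step of no change at the digits printed from compound 1 to compound 3 (within the scatter).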

Compound 3, minimum cytotoxic concentration: 25000 nM
Compound 3: middle estimate and measured number agree at the digits printed, within the range that was stated.
By their numbers in this assay, from the lowest: compounds 1, 3 and 2 (each within the scatter of the next).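

In this assay, among these compounds, the first comparison here that differs in one place gives no change at the digits printed from compound 1 to compound 3 (within the scatter) for 1-methylethenyl in place of ethyl. At this position, two ring bonds from the ring sulfur, a group with 3 heavy atoms and a double bond outside the aromatic ring therefore reads the same as ethyl. No measurement shown here accounts for this result.

Still open, on these data alone, is whether an amine, a carboxylic acid or a longer chain at this position would also stay within the scatter of compound 1.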